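Isomeric chloro-phenyl variation on a shared oxadiazole-chromane series

The source may hold more compounds than are shown below. What is called first, only, known or untested is meant among the compounds shown, and "the series" means these compounds.

Measured compounds:
- compound 1, `COc1cc(-c2nnc(C3CCc4cc(F)ccc4O3)o2)cc(OC)c1OC` — 87000 nM
- compound 2, `Fc1ccc2c(c1)CCC(c1nnc(-c3ccccc3Cl)o1)O2` — 88000 nM
- compound 3, `Fc1ccc2c(c1)CCC(c1nnc(C3CCc4cc(F)ccc4O3)o1)O2` — 87000 nM

In a functional assay (a lower number here means a stronger inhibitor, a higher number a weaker inhibitor), compound 1 gives 87000 nM, compound 2 gives 88000 nM and compound 3 gives 87000 nM. Among the measured compounds shown here, the three numbers sit within the scatter of one another, so no compound can be set apart as more or less potent on this assay; all three are weak inhibitors at a similar level. Compound 2 therefore stands on the same footing as compound 1 and compound 3.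

Compound 4, `Fc1ccc2c(c1)CCC(c1nnc(-c3ccc(Cl)cc3)o1)O2`, is not yet measured. It differs from compound 2 in one place: 4-chlorophenyl in place of 2-chlorophenyl on an aromatic carbon. The two share every atom and differ only in how the chlorine is joined to the phenyl ring.

For the measured compounds named here, no step between measured compounds is known here, and nothing among the three measured compounds separates one chlorophenyl from another. A step of no more than the scatter, in either direction, is expected from compound 2 to compound 4, as no change at the digits printed from compound 2 to compound 4 (within the scatter). Compound 4 is estimated to give 88000 nM, with an expected range from 40000 nM to 160000 nM.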

Compound 4, half-maximal inhibitory concentration: 85900 nM
Compound 4: middle estimate off by 1.0-fold (0.01 log units), on the high side; the measured number falls inside the stated range.
By their numbers in this assay, from the lowest: compounds 4, 1, 3 and 2 (each within the scatter of the next).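

In this assay, among the compounds shown here, the isomer swap gives a 1.0-fold lower number from compound 2 to compound 4 (0.01 log units; within the scatter) and so provides the first direct reading at this position on the five-membered aromatic ring. With the same atoms on both sides, 4-chlorophenyl and 2-chlorophenyl cannot be told apart here, so the placement of chlorine on this phenyl ring has no readable effect on the number in this pair. No supporting data bear on this result, and the match between the two isomers remains unexplained.

Still open is whether this position can respond at all, as the compounds shown all sit at a similar weak level. A carboxylic acid or an aminomethyl group on this phenyl ring, or a pyridine in place of it, would test whether the number can move beyond the scatter.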